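This account rests on a few compounds, and the source may have more. Where it says the series, first, only, none or still open, it means among the compounds named here.

The measured compounds:
- compound 1, `O=C(/C(=C\c1ccccc1OCc1ccccc1)SCc1ccc(F)cc1)c1ccc(Cl)cc1`, gives 1000 nM in a functional assay on DU-145 cells (Homo sapiens) for inhibition, read by trypan blue exclusion, with a stated time of 96 h; on this read-out higher numbers stand for weaker inhibition of growth and lower numbers for stronger inhibition of growth
- compound 2, `COc1ccc(S/C(=C/c2ccccc2OCc2ccccc2)C(=O)c2ccc(Cl)cc2)cc1`, gives 1000 nM in this assay
- compound 3, `Cc1ccc(/C=C(/SCc2ccc(F)cc2)C(=O)c2ccc(Cl)cc2)s1`, gives in this assay only the limit > 100000 nM

Compound 1 and compound 2 share one core and differ in a single place: 4-methoxyphenyl in place of 4-fluorobenzyl on a sulfur. In this assay this change gave no change at the digits printed from compound 1 to compound 2 (within the scatter), so the two values cannot be told apart within the usual scatter. Compound 3 is built on a different core; the difference between the two cores is not broken down here. Compound 3 sits at the limit of > 100000 nM in this assay, at which 1 of the 3 values shown sits. That reading is a limit of the assay and not a number, so nothing more than a boundary is known for compound 3.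

Compound 4, `COc1ccc(S/C(=C/c2ccc(C)s2)C(=O)c2ccc(Cl)cc2)cc1`, has not yet been measured. It stands to compound 3 exactly as compound 2 stands to compound 1, with the same change made on the same kind of sulfur: 4-methoxyphenyl in place of 4-fluorobenzyl on a sulfur. Among the compounds with values here, because the only measured instance of this change gave no change at the digits printed from compound 1 to compound 2 (within the scatter), the change is not expected to move the value by more than the scatter here either. In this assay the step from compound 3 to compound 4 is therefore expected to be a number no higher from compound 3 to compound 4 (the limit leaves the size open). Compound 4 is expected to sit near 100000 nM, with a range from 30000 nM to 300000 nM. Compound 4 is thus expected to end up, most likely, as a limit rather than a number.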

Compound 4, concentration for 50% growth inhibition: 50000 nM
For compound 4 the middle estimate is 2.0-fold (0.30 log units) above the measured one; low and high end bracket the measured number.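

Set side by side, the swap of 4-fluorobenzyl for 4-methoxyphenyl on a sulfur compares across the two cores as follows: the same change on two cores in this assay, no change at the digits printed (within the scatter) from compound 1 to compound 2 and an at least 2.0-fold lower number (0.30 log units; that floor lies within the scatter) from compound 3 to compound 4; the limit leaves it open whether they differ

Compound 3 gives > 100000 nM in this assay, and this is a limit of the assay and not a number.

In this assay, going by these compounds, the change gave an at least 2.0-fold lower number from compound 3 to compound 4 (0.30 log units; that floor lies within the scatter), so the result fits a swap that carries over from one core to the other with little effect, but it does not establish this, as the true size of the step stays unknown and could be much larger than on the first core.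

Only 4-fluorobenzyl and 4-methoxyphenyl appear on the sulfur in the compounds shown, so it stays open how growth inhibition would respond to a plain benzyl there, or to a longer chain ending in an amine or a carboxylic acid. On these data alone, with just two cores bearing on the question, one of them read only through a limit, it is also open whether the swap would behave the same way on a third core.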